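The compounds below may be only part of what the source reports. "The series", "measured", "known", "first", "only" and "open" are said of these compounds alone.

Compound 1 `CCc1cccc2cc(C(=O)O)cnc12` carries a carboxy group on its core and, in a functional assay on the whole organism (strain Sprague-Dawley) for inhibition, with Rattus norvegicus as the target (on this read-out lower numbers stand for an effect already at smaller amounts and higher numbers for an effect only at larger amounts of compound), compound 1 gives 75 mg/kg. Compound 3 `CCc1cccc2cc(-c3nn[nH]n3)cnc12` keeps the same core with a 2H-tetrazol-5-yl in place of the carboxy group, and compound 3 gives 5 mg/kg. Going by the values given here, the step of a 15-fold lower number from compound 1 to compound 3 (1.18 log units; beyond the scatter) is the only change that has been followed with numbers on both sides. Compound 2 `COc1ccc(OC)c2ncc(-c3nn[nH]n3)cc12` was also tested, but for compound 2 this assay reports only a limit, > 50 mg/kg, which is the limit of > 50 mg/kg in this assay, at which 1 of the 3 values shown sits. Among the two compounds that returned a number, compound 1 therefore stands at the higher end, while compound 3 sits well below it.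

Compound 4 `O=C(O)c1cnc2c(F)cccc2c1` keeps the carboxy group of compound 1 and changes a different part of the core: fluoro in place of ethyl on an aromatic carbon. Among the compounds with values here, no measured step touches the ethyl group, so the one step that exists, from compound 1 to compound 3, does not bear on this change, and there is nothing to point in either direction. The expectation is that compound 4 stays close to compound 1, with any movement lying within the scatter: the step of a 1.2-fold higher number from compound 1 to compound 4 (0.08 log units; within the scatter) is estimated to be small. Compound 4 is accordingly expected to give 90 mg/kg, within a range from 30 mg/kg to 300 mg/kg.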

Compound 4, minimum effective dose: 150 mg/kg
Compound 4: the middle estimate sits 1.7-fold (0.22 log units) below what was measured; low and high end bracket the measured number.
By their numbers in this assay, from the lowest: compound 3; then compounds 1 and 4 (each within the scatter of the next).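

In this assay, the first change followed at the ethyl position, fluoro in place of ethyl on an aromatic carbon, gives a 2.0-fold higher number from compound 1 to compound 4 (0.30 log units; within the scatter). The earlier step changed only the carboxy group, and that step, a 15-fold lower number from compound 1 to compound 3 (1.18 log units; beyond the scatter), was large, whereas this one shows that, with the carboxy group kept, going from a group of 2 heavy atoms to one of 1 heavy atom at this place on the ring of carbon only leaves no difference that can be told from the scatter. So far, then, the number has moved clearly with the group on the other ring and not with this one, though a single step at each place is all that supports the contrast, and nothing measured here says why the two groups read alike.

As far as these compounds go, it remains open how a longer chain such as butyl, or an amine, would read at this same place on the core, since ethyl and fluoro alone do not show how far the position can be changed. Also open is whether fluoro in place of ethyl would read the same with the 2H-tetrazol-5-yl group of compound 3, as this exchange is shown only with the carboxy group in place.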